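Series notes: carbonyl-ring change and expectation for compound 4

The source may hold more compounds than are shown below. What is called first, only, known or untested is meant among the compounds shown, and "the series" means these compounds.

Compound 3 `CN(C(=O)NC(=O)c1ccc(C(F)(F)F)cc1)c1nc(C(F)(F)F)c(C(=O)N/N=C/c2cccc(C(F)(F)F)c2)s1` gives 7.95 ug/mL in a functional assay on HepG2 cells (Homo sapiens) for inhibition, read by MTT assay, with a stated time of 72 h; on this read-out higher numbers stand for weaker inhibition and lower numbers for stronger inhibition. Compound 1 `CN(C(=O)NC(=O)c1c(F)cccc1F)c1nc(C(F)(F)F)c(C(=O)N/N=C/c2cccc(C(F)(F)F)c2)s1` differs from compound 3 by 2,6-difluorophenyl in place of 4-(trifluoromethyl)phenyl on a carbonyl carbon. In this assay compound 1 gives 27.9 ug/mL. The step is a 3.5-fold higher number from compound 3 to compound 1 (0.55 log units; beyond the scatter). Compound 2 `CN(C(=O)NC(=O)c1ccc(C(F)(F)F)cc1)c1nc(C(F)(F)F)c(C(=O)N/N=C/c2ccc(C(F)(F)F)cc2)s1` gives only a limit in this assay, > 100 ug/mL. Compound 2 differs from compound 3 by 4-(trifluoromethyl)phenyl in place of 3-(trifluoromethyl)phenyl on a carbon with a double bond to nitrogen, and the step from compound 2 to compound 3 in this assay is an at least 12-fold lower number from compound 2 to compound 3 (1.09 log units; beyond the scatter), so the position of the trifluoromethyl on the ring at the carbon with a double bond to nitrogen matters strongly within these three compounds.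

Compound 4 `CN(C(=O)NC(=O)c1c(F)cccc1F)c1nc(C(F)(F)F)c(C(=O)N/N=C/c2ccc(C(F)(F)F)cc2)s1` is not yet measured. It differs from compound 2 by 2,6-difluorophenyl in place of 4-(trifluoromethyl)phenyl on a carbonyl carbon, the same change already seen from compound 3 to compound 1, at a place described in the same words. That earlier change gave a 3.5-fold higher number from compound 3 to compound 1 (0.55 log units; beyond the scatter). The same direction is expected here, giving a step that the limit leaves unreadable from compound 2 to compound 4. Because compound 2 already sits at the limit of > 100 ug/mL in this assay, at which 1 of the 3 values shown sits, compound 4 is expected to report a limit as well in this assay. The estimate for compound 4 is 200 ug/mL, with a range of 70 ug/mL to 600 ug/mL.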

Compound 4, half-maximal inhibitory concentration: 49.6 ug/mL
Estimate against measurement, compound 4: 4.0-fold (0.61 log units) above, outside the stated range (below it).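

In this assay the change from 4-(trifluoromethyl)phenyl to 2,6-difluorophenyl on a carbonyl carbon gives an at least 2.0-fold lower number from compound 2 to compound 4 (0.30 log units; that floor lies within the scatter), and it does not carry over unchanged from one core to the other: the same change on two cores in this assay, a 3.5-fold higher number (0.55 log units; beyond the scatter) from compound 3 to compound 1 and an at least 2.0-fold lower number (0.30 log units; that floor lies within the scatter) from compound 2 to compound 4, at least 7.0-fold (0.84 log units) apart, beyond the scatter of two such steps. Compound 2 reports only a limit, > 100 ug/mL, so only a floor for that step can be read, not its size, and the two pairs give no cause for the gap. With 2,6-difluorophenyl on the carbonyl carbon, moving the trifluoromethyl on the ring at the carbon with a double bond to nitrogen gives a 1.8-fold higher number from compound 1 to compound 4 (0.25 log units; within the scatter), so the two changes cannot be treated as independent in these four compounds: the same change on two cores in this assay, an at least 12-fold lower number (1.09 log units; beyond the scatter) from compound 2 to compound 3 and a 1.8-fold lower number (0.25 log units; within the scatter) from compound 4 to compound 1, at least 7.0-fold (0.84 log units) apart, beyond the scatter of two such steps.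

The compounds shown leave open whether this dependence extends beyond trifluoromethyl and fluorine substituents, for instance to a nitrile or an amine on either ring. They also leave open how a carboxylic acid in place of the trifluoromethyl on the ring at the carbon with a double bond to nitrogen would read out.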